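A few compounds are considered here, and "the series" means these few. Any claim that something is new, unique, unknown or untested is made for them only; others in the source may bear on it.

Of the compounds shown here, three built on the same core have been measured in a functional assay on XF498 cells (Homo sapiens) for antiproliferative activity, read by MTT assay, with a stated time of 96 h; a lower number here means a stronger inhibitor, a higher number a weaker inhibitor. Compound 1 `O=C1C2=C(C(=O)c3ncccc31)C1(CS2)NC(=O)N(c2ccc(Cl)cc2)C1=O` gives 590 nM. Compound 2 `O=C1C2=C(C(=O)c3ncccc31)C1(CS2)NC(=O)N(c2ccccc2)C1=O` gives 1510 nM, and compound 3 `Cc1ccc(N2C(=O)NC3(CSC4=C3C(=O)c3ncccc3C4=O)C2=O)cc1` gives 1350 nM. Among these three numbers compound 3 stands second highest: the step of a 1.1-fold lower number from compound 2 to compound 3 (0.05 log units; within the scatter) lies within the scatter, whereas the step of a 2.3-fold higher number from compound 1 to compound 3 (0.36 log units; beyond the scatter) lies beyond it, as does a 2.6-fold higher number from compound 1 to compound 2 (0.41 log units; beyond the scatter).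

Compound 4 `CCCCc1ccc(N2C(=O)NC3(CSC4=C3C(=O)c3ncccc3C4=O)C2=O)cc1` differs from compound 3 by propyl in place of hydrogen on a saturated chain carbon bound to an aromatic carbon, which read one bond further out is methyl to butyl, or 4-methylphenyl to 4-butylphenyl. Going by the values given here, the only measured step that bears on this change is a 1.1-fold lower number from compound 2 to compound 3 (0.05 log units; within the scatter), where methyl in place of hydrogen at this place left the number within the scatter. Among the compounds with values here, no measured step covers a longer chain at this place, so the expectation rests on that single step, and a step of no more than the scatter is expected. The expected step is a 1.2-fold higher number from compound 3 to compound 4 (0.07 log units; within the scatter). Compound 4 is therefore estimated at 1600 nM, with a range from 550 nM to 4800 nM.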

Compound 4, half-maximal inhibitory concentration: 950 nM
Beside the measured number, compound 4's estimate is 1.7-fold (0.23 log units) above it; the range from low to high includes it.
By their numbers in this assay, from the lowest: compounds 1, 4, 3 and 2 (each within the scatter of the next, the first and the last beyond it).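

In this assay, lengthening the chain from 4-methylphenyl to 4-butylphenyl gives a 1.4-fold lower number from compound 3 to compound 4 (0.15 log units; within the scatter), so at this place a butyl group, like the methyl before it, leaves the number within the scatter. Against the other two compounds, butyl in place of hydrogen gives a 1.6-fold lower number from compound 2 to compound 4 (0.20 log units; within the scatter) and butyl in place of chloro gives a 1.6-fold higher number from compound 1 to compound 4 (0.21 log units; within the scatter), so compound 4 cannot be told apart from any of the other three compounds, even though compound 1 stands apart from compound 2 and compound 3 by steps beyond the scatter. Nothing available explains this result.

From the compounds shown here alone, whether a still longer chain, an amine or a carboxylic acid at this place would also stay within the scatter remains open. So does whether fluoro or bromo there would match chloro, the only group so far separated from hydrogen by more than the scatter.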